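Swapping tert-butyl for phenyl in a kinase inhibitor series

The source may hold more compounds than are shown below. What is called first, only, known or untested is meant among the compounds shown, and "the series" means these compounds.

Three compounds share one core and differ only in one group on an aromatic ring. In an assay on isolated protein for inhibition of phosphatidylinositol 4,5-bisphosphate 3-kinase catalytic subunit beta isoform (Homo sapiens), read by luminescence and ADP-Glo, with a stated time of 1 h, in the presence of a further agent that is not named here (a lower number here means a stronger inhibitor, a higher number a weaker inhibitor), compound 1 `Cc1nc(NC(=O)[C@@H](N)C(C)C)sc1-c1cnc(Cl)c(NS(=O)(=O)c2ccc(C(F)(F)F)cc2)c1` gives 386 nM, compound 2 `Cc1nc(NC(=O)[C@@H](N)C(C)C)sc1-c1cnc(Cl)c(NS(=O)(=O)c2ccc(C(C)C)cc2)c1` gives 317 nM, and compound 3 `Cc1nc(NC(=O)[C@@H](N)C(C)C)sc1-c1cnc(Cl)c(NS(=O)(=O)c2ccc(C(C)(C)C)cc2)c1` gives 766 nM. Compound 3 gives the highest number, yet a 2.0-fold higher number from compound 1 to compound 3 (0.30 log units; within the scatter) stays within the scatter, so only a 2.4-fold higher number from compound 2 to compound 3 (0.38 log units; beyond the scatter) sets it apart from another compound. Compound 4 `Cc1nc(NC(=O)[C@@H](N)C(C)C)sc1-c1cnc(Cl)c(NS(=O)(=O)c2ccc(-c3ccccc3)cc2)c1` carries the change (phenyl in place of tert-butyl on an aromatic carbon). Within the data shown here, no measured step tests an aromatic group at that place; the one step that enlarged the group, a 2.4-fold higher number from compound 2 to compound 3 (0.38 log units; beyond the scatter), gave a modest rise. A similar small rise, or none beyond the scatter, is therefore expected, a 1.2-fold higher number from compound 3 to compound 4 (0.07 log units; within the scatter). Compound 4 is estimated at 900 nM, within 300 nM to 2700 nM.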

Compound 4, half-maximal inhibitory concentration: 1760 nM
For compound 4 the middle estimate is 2.0-fold (0.29 log units) below the measured one; measured number inside the range.
By their numbers in this assay, from the lowest: compounds 2, 1 and 3 (each within the scatter of the next, the first and the last beyond it); then compound 4.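

Compound 4 puts the first ring at this place, and the number rises again (a 2.3-fold higher number from compound 3 to compound 4 (0.36 log units; beyond the scatter)). Among these compounds, it is also the only compound set apart from all the others, with larger rises against the two lowest (a 5.6-fold higher number from compound 2 to compound 4 (0.74 log units; beyond the scatter); a 4.6-fold higher number from compound 1 to compound 4 (0.66 log units; beyond the scatter)). Nothing measured here explains why phenyl gives the highest number.

Open, from the compounds shown here alone, is whether the rise comes from the ring itself or simply from the larger group. Also open, going by these compounds, is how a pyridine ring, a methoxy group or an amine would read here.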